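Swapping the methylphenyl arm for a bicyclic ether

The compounds below may be only part of what the source reports. "The series", "measured", "known", "first", "only" and "open" are said of these compounds alone.

Of the compounds shown here, three have been measured in an assay on isolated protein for inhibition of Long-chain-fatty-acid--CoA ligase 1 (Homo sapiens), read by mass spectrometry, with a stated time of 90 min, in the presence of a further agent that is not named here; a lower number here means a stronger inhibitor, a higher number a weaker inhibitor. Compound 1 `O=C(O)[C@H]1CC[C@@H](Oc2ccc3oc(-c4ccccc4)nc3c2)CC1` gives 4400 nM. Compound 3 `Cc1cccc(Cc2cc3cc(O[C@H]4CC[C@@H](C(=O)O)CC4)ccc3n2C)c1` gives 400 nM. Compound 2 `Cc1cccc(Cc2nc3cc(O[C@H]4CC[C@@H](C(=O)O)CC4)ccc3n2C)c1` gives 42 nM, the lowest of the three numbers; its gap to compound 3 and its larger gap to compound 1 both lie beyond the usual scatter, so compound 2 is the most potent of the measured set. Within the data shown here, no pair among the measured compounds differs in a single place, so no step within the set has been worked out.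

Compound 4 `Cn1c(Cc2ccc3c(c2)OCC3)nc2cc(O[C@H]3CC[C@@H](C(=O)O)CC3)ccc21` has not been measured. It differs from compound 2 in one place: a group of 9 heavy atoms (8 carbon, 1 oxygen; one five-membered non-aromatic ring with 1 hetero atom, one six-membered aromatic ring of carbon only) in place of a group of 7 heavy atoms (7 carbon; one six-membered aromatic ring of carbon only), on a saturated chain carbon bound to an aromatic carbon. The shared core and the carboxylic acid carried on the saturated ring are kept unchanged.

Among the measured compounds shown here, with no step of this kind among the measured compounds, the size of the change can only be guessed. The expectation is that compound 4 stays close to compound 2, with a step from compound 2 to compound 4 that is estimated as a 1.9-fold higher number from compound 2 to compound 4 (0.28 log units; within the scatter), toward a somewhat higher number but likely within the scatter. Compound 4 is therefore expected to give about 80 nM in this assay, with a plausible range from 25 nM to 300 nM.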

Compound 4, half-maximal inhibitory concentration: 13 nM
Beside the measured number, compound 4's estimate is 6.2-fold (0.79 log units) above it, and the stated range ends above it.
By their numbers in this assay, from the lowest: compound 4; then compound 2; then compound 3; then compound 1.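

Among these compounds, this is the first step in the set that can be read, and it shows that the position on a saturated chain carbon bound to an aromatic carbon is not tied to 3-methylphenyl. In this assay, putting the group of 9 heavy atoms in place of that arm gives a 3.2-fold lower number from compound 2 to compound 4 (0.51 log units; beyond the scatter), a modest gain that lies beyond the scatter, so a larger group with a second ring and one hydrogen-bond acceptor is accepted here and does better than the group it replaces. No measurement bears on why the number falls.

The single step changes the ring count and the oxygen together, so the compounds shown leave open which of the two goes with the lower number; a 3-methoxyphenyl group, which keeps an oxygen without the second ring, or the all-carbon ring analogue, with a methylene in place of the ring oxygen, would separate them. Also open, as far as these compounds go, is whether the same swap gives a similar step on the cores of compound 1 and compound 3, and whether the carboxylic acid on the saturated ring can be replaced by a tetrazole.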